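Can a chloro swap lift compound 1 off the limit?

A few compounds are considered here, and "the series" means these few. Any claim that something is new, unique, unknown or untested is made for them only; others in the source may bear on it.

Measured in a functional assay on T47D cells (Homo sapiens) for antiproliferative activity, read by MTT assay, with a stated time of 72 h (a higher number here means a weaker inhibitor, a lower number a stronger inhibitor), each value a limit and not a number:
- compound 1 `O=C(Nc1ccc(Cl)c(-c2nnc3c(Cl)cccn23)c1)c1ccc(F)cc1Cl` gives > 100000 nM
- compound 2 `O=C(Nc1ccc(Cl)c(-c2nnc3c(Cl)cccn23)c1)c1ccccn1` gives > 100000 nM
- compound 3 `O=C(Nc1ccc(Cl)c(-c2nnc3c(Cl)cccn23)c1)c1cccnc1` gives > 100000 nM

Compound 1 therefore has no exact position on the scale. Its value > 100000 nM is only a limit. Among the compounds with values here, the whole set sits together, with the limit of > 100000 nM in this assay, at which 3 of the 3 values shown sit, as the only evidence on where these compounds stand.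

The untested compound 4 `O=C(Nc1ccc(Cl)c(-c2nnc3c(Cl)cccn23)c1)c1ccc(Cl)cc1` changes one group on the carbonyl carbon: 4-chlorophenyl in place of 2-chloro-4-fluorophenyl on a carbonyl carbon. In words, 4-chlorophenyl replaces 2-chloro-4-fluorophenyl.

Two measured changes at that same place bear on this one: a step that the two limits leave unreadable from compound 1 to compound 2 and a step that the two limits leave unreadable from compound 1 to compound 3. Neither gives a size, so they offer no evidence for a gain or a loss. No change beyond the usual scatter is expected in either direction, and the expected step is a number no higher from compound 1 to compound 4 (the limit leaves the size open).

Compound 4 is estimated at 100000 nM, with an expected range from 40000 nM to 250000 nM.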

Compound 4, half-maximal inhibitory concentration: > 100000 nM
Compound 4 ended at the assay's limit; the forecaster's own chance of this, stated with the estimate: 75%; the middle value lies on the limit itself.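

In this assay compound 4 gives > 100000 nM as a limit and not a number. The steps from compound 1, compound 2 and compound 3 to compound 4 cannot be read, since all four compounds sit at one limit: the limit of > 100000 nM in this assay, at which 4 of the 4 values shown sit. The compounds shown leave open whether this assay would give an exact value for any group on the carbonyl carbon.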